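Working notes: homologating the amine on the shared core

The compounds below may be only part of what the source reports. "The series", "measured", "known", "first", "only" and "open" are said of these compounds alone.

The series is followed in a functional assay on HeLa cells (Homo sapiens) for cytotoxicity, read by neutral red uptake, with a stated time of 3 days; on this read-out higher numbers stand for weaker inhibition and lower numbers for stronger inhibition. Compound 1 `C[S+]([O-])c1c(F)c(N)c2c(=O)cc(-c3ccc(N)c(F)c3)oc2c1F` gives a limit, > 100000 nM, in this assay. Compound 2 `Nc1ccc(-c2cc(=O)c3c(N)c(F)c(O)c(F)c3o2)cc1F` likewise gives a limit, > 100000 nM. Compound 3 `CN(C)c1c(F)c(N)c2c(=O)cc(-c3ccc(N)c(F)c3)oc2c1F` also stops at a limit, > 100000 nM. All three values thus sit at the limit of > 100000 nM in this assay, at which 3 of the 3 values shown sit, and the steps among them, a step that the two limits leave unreadable from compound 1 to compound 2, a step that the two limits leave unreadable from compound 1 to compound 3 and a step that the two limits leave unreadable from compound 2 to compound 3, carry no readable size. Compound 4 `CN(C)Cc1c(F)c(N)c2c(=O)cc(-c3ccc(N)c(F)c3)oc2c1F` differs from compound 3 by (dimethylamino)methyl in place of dimethylamino on an aromatic carbon. Among the compounds with values here, no measured step bears on this exchange, and the three unreadable steps give no direction, so no step beyond the scatter is expected in this assay, with a limit again the likeliest outcome. For compound 4 the estimate is 100000 nM, within 30000 nM to 300000 nM. The corresponding step, a number no higher from compound 3 to compound 4 (the limit leaves the size open), is what is expected.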

Compound 4, half-maximal inhibitory concentration: 8900 nM
Compound 4: middle estimate off by 11-fold (1.05 log units), on the high side; measured number below the stated range.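

In this assay, within the data shown here, (dimethylamino)methyl on this aromatic carbon brings the first readable number to the series, with an at least 11-fold lower number from compound 3 to compound 4 (1.05 log units; beyond the scatter), so this position does respond to the exchange for dimethylamino. The same group also gives an at least 11-fold lower number from compound 2 to compound 4 (1.05 log units; beyond the scatter) against hydroxy and an at least 11-fold lower number from compound 1 to compound 4 (1.05 log units; beyond the scatter) against the group of compound 1. Each of these sizes is a bound and not a full measure, as one end of each step is a limit: the limit of > 100000 nM in this assay, at which 3 of the 4 values shown sit.

The compounds shown leave open whether the extra carbon or the amine on it carries the step. Also open, going by these compounds, is whether a longer chain such as (dimethylamino)ethyl, or a morpholinomethyl group, would hold the number or move it further.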